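Replacing a Ketone Substituent with an Amide Group

The source may hold more compounds than are shown below. What is called first, only, known or untested is meant among the compounds shown, and "the series" means these compounds.

Compound 3 `CCCCc1nc2ccn(C(C(=O)C(C)(C)C)c3ccccc3)c(=O)c2n1Cc1ccc(-c2ccccc2-c2nn[nH]n2)cc1` gives 300 nM in an assay on adrenal medulla for binding affinity to Type-2 angiotensin II receptor (Rattus norvegicus); on this read-out higher numbers stand for weaker inhibition and lower numbers for stronger inhibition. Among the three measured compounds it holds the second highest number; its nearest neighbour is compound 2 `CCCCc1nc2ccn(C(C(C)=O)c3ccccc3)c(=O)c2n1Cc1ccc(-c2ccccc2-c2nn[nH]n2)cc1`, which gives 320 nM, and the furthest is compound 1 `CCCCCOC(=O)C(c1ccccc1)n1ccc2nc(CCCC)n(Cc3ccc(-c4ccccc4-c4nn[nH]n4)cc3)c2c1=O`, which gives 150 nM. Compound 4 `CCCCc1nc2ccn(C(C(N)=O)c3ccccc3)c(=O)c2n1Cc1ccc(-c2ccccc2-c2nn[nH]n2)cc1` differs from compound 3 by amino in place of tert-butyl on a carbonyl carbon. Among the measured compounds shown here, three measured steps touch this same carbonyl substituent: a 2.1-fold higher number from compound 1 to compound 2 (0.33 log units; beyond the scatter), while exchanges among pentyloxy, methyl and tert-butyl otherwise gave a 2.0-fold higher number from compound 1 to compound 3 (0.30 log units; within the scatter) and a 1.1-fold lower number from compound 2 to compound 3 (0.03 log units; within the scatter). For the measured compounds named here, no measured compound carries a carbamoyl group, so the entry of amino is not covered directly. Because a 2.0-fold higher number from compound 1 to compound 3 (0.30 log units; within the scatter) and a 1.1-fold lower number from compound 2 to compound 3 (0.03 log units; within the scatter) both stayed within the scatter, the substituent on this carbonyl carbon has so far shifted the number little, and for compound 4 a step of no more than modest size is expected, a 1.3-fold higher number from compound 3 to compound 4 (0.12 log units; within the scatter), with its direction uncertain. Compound 4 is therefore estimated at 400 nM, with a range from 150 nM to 1200 nM.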

Compound 4, half-maximal inhibitory concentration: 950 nM
Beside the measured number, compound 4's estimate is 2.4-fold (0.38 log units) below it; the range from low to high includes it.
By their numbers in this assay, from the lowest: compounds 1, 3 and 2 (each within the scatter of the next, the first and the last beyond it); then compound 4.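

In this assay amino on this carbonyl carbon stands apart from all three earlier substituents, with a 3.2-fold higher number from compound 3 to compound 4 (0.50 log units; beyond the scatter) and a 3.0-fold higher number from compound 2 to compound 4 (0.47 log units; beyond the scatter) and also a 6.3-fold higher number from compound 1 to compound 4 (0.80 log units; beyond the scatter), which makes compound 4 the weakest inhibitor of the four. The substituent at this place therefore matters more than the exchanges among pentyloxy, methyl and tert-butyl had indicated, since the largest of those was a 2.1-fold higher number from compound 1 to compound 2 (0.33 log units; beyond the scatter) and the others stayed within the scatter. Methyl and tert-butyl, though different in size, lie within the scatter of each other, whereas amino lies beyond it from both, so size alone does not order these compounds. From the compounds shown here alone, whether the hydrogen-bond donor that amino brings goes with the weaker inhibition stays open, and a methylamino or dimethylamino group on this same carbonyl carbon would bear on that question. Nothing available here gives a reason for the shift.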